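Compound 3: an amide swap on the pyrrolidine

The compounds below may be only part of what the source reports. "The series", "measured", "known", "first", "only" and "open" are said of these compounds alone.

Compound 1 `O=C(CN1CCNCC1)N1CCC(NS(=O)(=O)c2cc(S(=O)(=O)c3ccccc3)ccc2C(F)(F)F)CC1` gives 50000 nM in a physicochemical assay for solubility; a higher number here means a more soluble compound, a lower number a less soluble compound
Compound 2 `CC(C)(C)OC(=O)N1CCC[C@@H]1C(=O)N1CCC(NS(=O)(=O)c2cc(S(=O)(=O)c3ccccc3)ccc2C(F)(F)F)CC1` gives 25000 nM in this assay

Among the compounds with values here, only one other compound has been measured, and compound 2 stands at 25000 nM within the scatter of it. Compound 3 `CC(C)C(=O)N1CCC[C@H]1C(=O)N1CCC(NS(=O)(=O)c2cc(S(=O)(=O)c3ccccc3)ccc2C(F)(F)F)CC1` differs from it by 1-(isopropylcarbonyl)pyrrolidin-2-yl in place of 1-(tert-butoxycarbonyl)pyrrolidin-2-yl on a carbonyl carbon with 1-(isopropylcarbonyl)pyrrolidin-2-yl in place of 1-(tert-butoxycarbonyl)pyrrolidin-2-yl on a carbonyl carbon. Within the data shown here, the one measured step bearing on this is a 2.0-fold lower number from compound 1 to compound 2 (0.30 log units; within the scatter) on that same carbonyl carbon. Given that small step, no change beyond the scatter is expected in this assay and no direction is favoured. The expected step is a 1.2-fold higher number from compound 2 to compound 3 (0.08 log units; within the scatter) and would stay within the scatter. The estimated value for compound 3 is 30000 nM with an expected range from 12000 nM to 60000 nM for repeated measurements.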

Compound 3, solubility: 100000 nM
Compound 3: middle estimate off by 3.3-fold (0.52 log units), on the low side, and the stated range ends below it.
By their numbers in this assay, from the lowest: compounds 2, 1 and 3 (each within the scatter of the next, the first and the last beyond it).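

Within the data shown here, on this carbonyl carbon, 1-(isopropylcarbonyl)pyrrolidin-2-yl replacing 1-(tert-butoxycarbonyl)pyrrolidin-2-yl gives a 4.0-fold higher number from compound 2 to compound 3 (0.60 log units; beyond the scatter) in this assay, the first step at this place to pass the scatter. Set against (piperazin-1-yl)methyl, the same group gives a 2.0-fold higher number from compound 1 to compound 3 (0.30 log units; within the scatter), so this assay does not separate these two groups. Nothing measured here accounts for the step from the tert-butoxycarbonyl group. The compounds shown leave open whether a free amine or a longer acyl chain in place of isopropylcarbonyl would shift the number in this assay.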